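The source may hold more compounds than are shown below. What is called first, only, known or untested is meant among the compounds shown, and "the series" means these compounds.

Compound 1 `N/C(=N\NC(=S)N1CCCC1)c1ccc(F)cn1`: in a functional assay on HeLa cells (Homo sapiens) for cytotoxicity, read by MTT assay, with a stated time of 72 h, tested at 100 uM (on this read-out higher numbers stand for more inhibition of growth at the one concentration tested and lower numbers for less inhibition of growth), compound 1 gives 85.4%.
Compound 2 `N/C(=N\NC(=S)N1CCSCC1)c1ccc(F)cn1`: in this assay compound 2 gives 88.1%.
Compound 3 `N/C(=N\NC(=S)N1CCOCC1)c1ccc(F)cn1`: in this assay compound 3 gives 81.2%.

Compound 1 stands second highest of the three numbers in this assay, with its neighbours close on either side: a number 2.7 percentage points higher from compound 1 to compound 2 (within the scatter), a number 4.2 percentage points lower from compound 1 to compound 3 (within the scatter), and likewise a number 6.9 percentage points lower from compound 2 to compound 3 (within the scatter). All three steps exchange the amine on the thiocarbonyl carbon, and none of them moves the number beyond the scatter.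

Compound 4 `N/C(=N\NC(=S)N1CCCC1)c1ccccn1` differs from compound 1 at another place: hydrogen in place of fluoro on an aromatic carbon. Among the measured compounds shown here, no measured step touches that aromatic carbon, so none of the three bears directly on the change. For the measured compounds named here, they show only that the shared core, carrying fluoro, gives numbers within the scatter of one another whatever the amine. Going by the values given here, with no step to go by, the account expects no change beyond the scatter in this assay from compound 1 to compound 4, but allows a wider range than for a change already sampled. Compound 4 is therefore estimated at 80%, between 60% and 95%. The expected step is a number 5.4 percentage points lower from compound 1 to compound 4 (within the scatter).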

Compound 4, percent growth inhibition at one concentration: 89.1%
Compound 4: the middle estimate sits 9.1 percentage points below what was measured; measured number inside the range.
By their numbers in this assay, from the lowest: compounds 3, 1, 2 and 4 (each within the scatter of the next).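

Hydrogen in place of fluoro on this aromatic carbon, para to a large group, gives a number 3.7 percentage points higher from compound 1 to compound 4 (within the scatter) in this assay. Among the compounds shown here, this is the first step at this position, and it shows that, with pyrrolidin-1-yl on the thiocarbonyl carbon, the fluoro is not needed for the growth inhibition seen at the one concentration tested. Nothing available offers an explanation for this result. From the compounds shown here alone, whether a larger group at this carbon, such as methoxy, an amine or trifluoromethyl, would leave the number within the scatter remains open, as does whether the same exchange behaves alike with morpholin-4-yl or thiomorpholin-4-yl in place of pyrrolidin-1-yl. Going by these compounds, with a single concentration, it also remains open whether these compounds would still read alike at lower concentrations.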